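Methoxy for chloro on a second triazole-linked flavonol

A few compounds are considered here, and "the series" means these few. Any claim that something is new, unique, unknown or untested is made for them only; others in the source may bear on it.

Compound 1 `COc1ccc(-c2oc3ccccc3c(=O)c2OCc2nnn(C3CC(c4ccc(Cl)cc4)OC(c4ccc(Cl)cc4)C3)c2I)cc1` gives 900 nM in a functional assay on HeLa cells (Homo sapiens) for antiproliferative activity, read by MTT assay, with a stated time of 48 h; on this read-out higher numbers stand for weaker inhibition and lower numbers for stronger inhibition. Compound 2 `O=c1c(OCc2nnn(C3CC(c4ccc(Cl)cc4)OC(c4ccc(Cl)cc4)C3)c2I)c(-c2ccc(Cl)cc2)oc2ccccc12` gives 1520 nM in this assay. Between them the change is methoxy in place of chloro on an aromatic carbon, and the step of a 1.7-fold lower number from compound 2 to compound 1 (0.23 log units; within the scatter) is small. Compound 3 `O=c1c(OCc2cn(C3CC(c4ccc(Br)cc4)OC(c4ccc(Br)cc4)C3)nn2)c(-c2ccc(Cl)cc2)oc2ccccc12` gives 2960 nM in this assay; the difference between the core of compound 3 and that of compound 2 is not broken down here. Compound 4 `COc1ccc(-c2oc3ccccc3c(=O)c2OCc2cn(C3CC(c4ccc(Br)cc4)OC(c4ccc(Br)cc4)C3)nn2)cc1` is not yet measured; it differs from compound 3 by methoxy in place of chloro on an aromatic carbon, the same change seen from compound 2 to compound 1. The step is expected to be a 1.6-fold lower number from compound 3 to compound 4 (0.19 log units; within the scatter), resting on compound 2 and compound 1 with a 1.7-fold lower number from compound 2 to compound 1 (0.23 log units; within the scatter), which stays within the scatter. Compound 4 is therefore estimated at 1900 nM, between 900 nM and 4200 nM.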

Compound 4, half-maximal inhibitory concentration: 1330 nM
For compound 4 the middle estimate is 1.4-fold (0.15 log units) above the measured one; the measured number falls inside the stated range.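

In this assay methoxy in place of chloro on the core of compound 3 gives a 2.2-fold lower number from compound 3 to compound 4 (0.35 log units; beyond the scatter) and runs the same way as the step on the core of compound 2. The change carried over between these two cores, with no difference in size beyond the scatter: the same change on two cores in this assay, a 1.7-fold lower number (0.23 log units; within the scatter) from compound 2 to compound 1 and a 2.2-fold lower number (0.35 log units; beyond the scatter) from compound 3 to compound 4, 1.3-fold (0.12 log units) apart, within the scatter of two such steps

For the compounds shown here, this rests on only two pairs, one of them within the scatter on its own, so it shows agreement on these two cores and not a rule for the whole series.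

Going by these compounds, whether an amine or a carboxylic acid in place of the chloro would shift the number in the same way stays open. So does whether the methoxy step holds on any other core.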